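Swapping 4-Chlorophenyl for 3-Methoxyphenyl on the Shared Core

The source may hold more compounds than are shown below. What is called first, only, known or untested is meant among the compounds shown, and "the series" means these compounds.

- Compound 1 `COc1cc(-n2ncnc2-c2ccc(C)cc2)cc(OC)c1OC` gives 250 nM
- Compound 2 `COc1cc(-n2ncnc2-c2ccc(Cl)cc2)cc(OC)c1OC` gives > 10000 nM

In a functional assay on HeLa cells (Homo sapiens) for antiproliferative activity, read by MTT assay, with a stated time of 72 h (a higher number here means a weaker inhibitor, a lower number a stronger inhibitor), compound 2 gives > 10000 nM and this is a limit of the assay, not a number. Compound 3 `COc1cccc(-c2ncnn2-c2cc(OC)c(OC)c(OC)c2)c1` carries 3-methoxyphenyl in place of 4-chlorophenyl on an aromatic carbon of the shared core (3-methoxyphenyl in place of 4-chlorophenyl on an aromatic carbon). For the measured compounds named here, one measured step bears on this: an at least 40-fold higher number from compound 1 to compound 2 (1.60 log units; beyond the scatter) and it is large. It shows that a change on this same aromatic group can move the result strongly. Going by the values given here, no measured compound carries a methoxy group there, so the size of the step stays uncertain. Compound 1 gives 250 nM in this assay and this suggests that leaving chloro behind may restore activity. For compound 3 the expected step is an at least 6.6-fold lower number from compound 2 to compound 3 (0.82 log units; beyond the scatter) toward a lower number. For compound 3 the estimate is 1500 nM (from 150 nM to 10000 nM).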

Compound 3, half-maximal inhibitory concentration: > 10000 nM
Compound 3: only a limit was reported; the forecaster's own chance of this, stated with the estimate: 25%; middle value at least 6.6-fold (0.82 log units) from the limit.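

Replacing 4-methylphenyl with 3-methoxyphenyl on this aromatic carbon of the shared core gives an at least 40-fold higher number from compound 1 to compound 3 (1.60 log units; beyond the scatter) in this assay, so a large step at this place is no longer tied to chloro alone. The step from compound 2 to compound 3 cannot be read, as both values are limits and not numbers, and so the 4-chlorophenyl and 3-methoxyphenyl groups cannot be ranked against each other. Of the three groups shown here, only the 4-methylphenyl of compound 1 gives a measured number, while compound 2 and compound 3 both stop at the same limit: the limit of > 10000 nM in this assay, at which 2 of the 3 values shown sit.

From the compounds shown here alone, it stays open what a plain phenyl, or a phenyl carrying an amine or a longer alkyl chain, would give at this place. Going by these compounds, it also stays open how far the activity of compound 1 depends on its methyl group.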